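The source may hold more compounds than are shown below. What is called first, only, known or untested is meant among the compounds shown, and "the series" means these compounds.

- compound 1 `CC(=O)SCCC(CCCCC(=O)O)SC(C)=O` gives 12.4%
- compound 2 `O=C(CCCCC1CCSS1)Nc1cccc2ccccc12` gives 8.37%
- compound 3 `CC(=O)SCCC(CCCCC(=O)Nc1ccccc1)SC(C)=O` gives 1.68%

All three numbers come from a functional assay on KB cells (Homo sapiens) for inhibition, read by MTT assay, with a stated time of 24 h, tested at 1 ug/mL (on this read-out higher numbers stand for more inhibition of growth at the one concentration tested and lower numbers for less inhibition of growth), and they leave compound 3 in a weak position. It cannot be told apart from compound 2, because the gap between them stays within the usual scatter, but it stands clearly under compound 1.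

Compound 4 `CC(=O)SCCC(CCCCC(=O)Nc1ccccc1Cl)SC(C)=O` differs from compound 3 in one place: chloro in place of hydrogen on an aromatic carbon is the whole change, which turns the phenyl into 2-chlorophenyl, with chloro in place of hydrogen on an aromatic carbon, ortho to a large group.

Among the compounds with values here, only one measured step is available as a guide: a number 10.7 percentage points lower from compound 1 to compound 3 (beyond the scatter) with anilino in place of hydroxy on a carbonyl carbon. That step was modest and sits elsewhere in the molecule. Within the data shown here, no measured pair shows what a chloro does on this ring, so no step beyond the scatter can be argued for. The estimated change is a number 3.3 percentage points higher from compound 3 to compound 4 (within the scatter) and it is expected to stay within the scatter. For compound 4 the estimated value is 5% (expected range 0% to 14% in repeated measurements).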

Compound 4, percent growth inhibition at one concentration: 8.21%
Beside the measured number, compound 4's estimate is 3.2 percentage points below it; measured number inside the range.
By their numbers in this assay, from the lowest: compounds 3, 4, 2 and 1 (each within the scatter of the next, the first and the last beyond it).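

In this assay, chloro in place of hydrogen on the aromatic ring, ortho to a large group, gives a number 6.5 percentage points higher from compound 3 to compound 4 (within the scatter) and so does not separate the two compounds. The comparison with the parent acid does change: anilino in place of hydroxy gave a number 10.7 percentage points lower from compound 1 to compound 3 (beyond the scatter) and a step beyond the scatter, while (2-chlorophenyl)amino in place of hydroxy gives a number 4.2 percentage points lower from compound 1 to compound 4 (within the scatter) and leaves those two compounds indistinguishable. Nothing available here explains this result.

One chloro at one ring position cannot show how a fluoro, methyl or methoxy group would behave there. It also leaves open what chloro would do elsewhere on the ring, and whether an amine on the ring would read any differently.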